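This account rests on a few compounds, and the source may have more. Where it says the series, first, only, none or still open, it means among the compounds named here.

In a functional assay on MCF7 cells (Homo sapiens) for inhibition, read by MTT assay, with a stated time of 72 h (on this read-out lower numbers stand for stronger inhibition and higher numbers for weaker inhibition), compound 1 `COc1cc(OC)c(OC)cc1/C=C/C(=O)c1ccc(Cl)cc1` gives 29500 nM and compound 2 `COc1cc(OC)c(OC)cc1/C=C/C(=O)c1ccc(Cl)c([N+](=O)[O-])c1` gives 16400 nM, two values within the scatter of each other. Compound 3 `COc1cc(OC)c(OC)cc1/C=C/C(=O)c1cccc([N+](=O)[O-])c1` departs from compound 2 as follows: hydrogen in place of chloro on an aromatic carbon. Among the measured compounds shown here, no measured step removes chloro. For the measured compounds named here, the only measured step, a 1.8-fold lower number from compound 1 to compound 2 (0.25 log units; within the scatter), placed nitro where hydrogen stood and bears on this change only indirectly. No shift beyond the scatter is therefore expected, and the estimated change is a 1.2-fold higher number from compound 2 to compound 3 (0.09 log units; within the scatter). For compound 3 the expected value is 20000 nM, with an estimated range of 8000 nM to 50000 nM.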

Compound 3, half-maximal inhibitory concentration: > 150000 nM
Compound 3: a limit, no number; the forecaster's own chance of this, stated with the estimate: 8%; middle value at least 7.5-fold (0.87 log units) from the limit.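

In this assay, hydrogen in place of chloro on an aromatic carbon, ortho to a nitro group, gives an at least 9.1-fold higher number from compound 2 to compound 3 (0.96 log units; beyond the scatter). Chloro at this position therefore carries a step beyond the scatter, whereas the earlier nitro change, a 1.8-fold lower number from compound 1 to compound 2 (0.25 log units; within the scatter), stayed within it. The value of compound 3 is a limit of the assay, not a number: the limit of > 150000 nM in this assay, at which 1 of the 3 values shown sits.

The compounds shown hold only chloro or hydrogen at this position, so whether a fluoro group, a methyl group or an amine would act like chloro stays open. As far as these compounds go, whether chloro counts for as much where no nitro group stands also remains open.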